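The source may report more compounds than this note shows. Statements on the series, on what has been measured and on what is new or still open speak of the compounds shown alone.

Measured compounds in the series:
- compound 1, `O=C(Nc1ccccc1)Nc1cccc(CNc2nccnc2Cl)c1`: 15600 nM
- compound 2, `CCc1ccc(NC(=O)Nc2cccc(CNc3nccnc3Cl)c2)c(CC)c1`: 10800 nM
- compound 3, `O=C(Nc1cccc(CNc2nccnc2Cl)c1)NC1CCCC1`: 18400 nM

In a functional assay on HepG2 cells (Homo sapiens) for antiproliferative activity, read by MTT assay, with a stated time of 48 h (a higher number here means a weaker inhibitor, a lower number a stronger inhibitor), compound 1 gives 15600 nM, the second highest of the three numbers; compound 3 sits nearest, and compound 2 furthest, both within the scatter of compound 1. For the measured compounds named here, the only measured step from compound 1 is a 1.2-fold higher number from compound 1 to compound 3 (0.07 log units; within the scatter), which changes nothing beyond the scatter.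

Compound 4, `Cc1ccc(NC(=O)Nc2cccc(CNc3nccnc3Cl)c2)c(C)c1`, is not yet measured. It differs from compound 1 in one place: 2,4-dimethylphenyl in place of phenyl on an amide-type nitrogen. Going by the values given here, no measured step covers this exact change. The closest comparison is compound 2, which carries a related substituted ring on the same amide-type nitrogen and gives 10800 nM, against 15600 nM for compound 1, a difference within the scatter. Among the compounds with values here, the one measured step at this position, a 1.2-fold higher number from compound 1 to compound 3 (0.07 log units; within the scatter), was also within the scatter. The expected step in this assay is therefore small, at most a slightly lower number, and the estimate for compound 4 is 12500 nM, in the range 6000 nM to 26000 nM, which means an expected step of a 1.2-fold lower number from compound 1 to compound 4 (0.10 log units; within the scatter).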

Compound 4, half-maximal inhibitory concentration: 9290 nM
Compound 4: the middle estimate sits 1.3-fold (0.13 log units) above what was measured, and the stated range covers the measured number.
By their numbers in this assay, from the lowest: compounds 4, 2, 1 and 3 (each within the scatter of the next).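

In this assay the swap to 2,4-dimethylphenyl on the amide-type nitrogen gives a 1.7-fold lower number from compound 1 to compound 4 (0.23 log units; within the scatter) and, starting from the cyclopentyl group, gives a 2.0-fold lower number from compound 3 to compound 4 (0.30 log units; within the scatter). Both steps stay within the scatter, so phenyl, cyclopentyl and 2,4-dimethylphenyl at this position cannot be told apart in this cell read-out, and adding methyl groups to the phenyl ring has not yet produced a step that stands clear of it. No evidence on hand speaks to what lies behind these numbers.

From the compounds shown here alone, whether an amine, a carboxylic acid or a methoxy group on this ring would move the number beyond the scatter remains open. The core is the same in all the compounds shown, so the effect of changing it also remains open.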